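The compounds below may be only part of what the source reports. "The series", "measured", "known", "first", "only" and "open" are said of these compounds alone.

Measured so far in an ADME assay on liver for metabolic stability, with Liver microsome (Homo sapiens) as the target, read by LC-MS, using microsomes; a higher number here means faster removal of the compound, a lower number slower removal:
Compound 1 `CC(C)(C)OC[C@@H](O)C(=O)N1[C@H](C(=O)NCc2cc(Cl)ccc2-n2cnnn2)C[C@@H]2C[C@@H]21`: 21 mL.min-1.g-1.
Compound 2 `CC(C)(C)[C@@H](O)C(=O)N1C[C@@H]2C[C@@H]2[C@H]1C(=O)NCc1cc(Cl)ccc1-n1cnnn1`: < 15 mL.min-1.g-1.
Compound 3 `CC(C)(C)[C@@H](O)C(=O)N1C[C@H]2C[C@H]2[C@H]1C(=O)NCc1cc(Cl)ccc1-n1cnnn1`: 22 mL.min-1.g-1.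

Compound 2 stands at the limit of < 15 mL.min-1.g-1 in this assay, at which 1 of the 3 values shown sits, so its entry is a limit and not a number. Compound 4 `O=C(NCc1cc(Cl)ccc1-n1cnnn1)[C@@H]1[C@H]2C[C@H]2CN1C(=O)[C@H](O)CC1CC1` departs from compound 2 in one group: cyclopropylmethyl in place of tert-butyl on a saturated chain carbon bound to a carbonyl carbon and an oxygen on a saturated carbon. In words, this is cyclopropylmethyl in place of tert-butyl on a saturated chain carbon bound to a carbonyl carbon and an oxygen on a saturated carbon.

Among the compounds with values here, no measured step exchanges this group, so none gives its size directly. The nearest guide is an at least 1.4-fold higher number from compound 2 to compound 3 (0.16 log units; that floor lies within the scatter). That step concerns the fact that compounds 2 and 3 differ only in the configuration as drawn and leaves the tert-butyl in place, so it bears on the new change only loosely. Within the data shown here, the one actual number on that step is that of compound 3 at 22 mL.min-1.g-1.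

A small rise in this assay is therefore expected, not far beyond the scatter, and compound 4 may yet report only a limit. The expected change is an at least 1.3-fold higher number from compound 2 to compound 4 (0.12 log units; that floor lies within the scatter). For compound 4 the estimated value is 20 mL.min-1.g-1, with an expected range of 12 mL.min-1.g-1 to 38 mL.min-1.g-1.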

Compound 4, intrinsic clearance in microsomes: < 14 mL.min-1.g-1
Compound 4 was reported as a limit; the forecaster's own chance of this, stated with the estimate: 30%; middle value at least 1.4-fold (0.15 log units) from the limit.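

In this assay compound 4 gives < 14 mL.min-1.g-1, which is a limit and not a number. Within the data shown here, compound 2 gives < 15 mL.min-1.g-1, also a limit, so no step between compound 2 and compound 4 can be read. The compounds shown leave open whether cyclopropylmethyl in place of tert-butyl changes the intrinsic clearance in microsomes at all, and in which direction.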